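Thiophene replaces oxadiazolone on the chloroaryl ring

The source may hold more compounds than are shown below. What is called first, only, known or untested is meant among the compounds shown, and "the series" means these compounds.

Measured so far:
compound 1 `Cn1nc2c(=O)n(CC3(O)CCN(Cc4ccc(-c5n[nH]c(=O)o5)cc4Cl)CC3)cnc2c1-c1ccc(CN)cc1` — 171 nM
compound 2 `Cn1nc2c(=O)n(CC3(O)CCN(Cc4ccc(-c5ccco5)cc4Cl)CC3)cnc2c1-c1ccc(CO)cc1` — 42.5 nM

Both were run in an assay on isolated protein for inhibition of ubiquitin carboxyl-terminal hydrolase 7 (Homo sapiens), with stated times of 30 min and 2 h; a lower number here means a stronger inhibitor, a higher number a weaker inhibitor. Compound 1 gives 171 nM and stands as the higher of the two numbers; compound 2 gives 42.5 nM, and the gap between them lies beyond the scatter. For the measured compounds named here, compound 2 differs from compound 1 in more than one place, so no single step is drawn between them; their two values show only that compound 2 is the stronger inhibitor of the pair.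

Compound 3 `Cn1nc2c(=O)n(CC3(O)CCN(Cc4ccc(-c5ccsc5)cc4Cl)CC3)cnc2c1-c1ccc(CN)cc1` is compound 1 with one change: a group of 5 heavy atoms (4 carbon, 1 sulfur; one five-membered aromatic ring with 1 hetero atom) in place of a group of 6 heavy atoms (2 carbon, 2 nitrogen, 2 oxygen; one five-membered aromatic ring with 3 hetero atoms), on an aromatic carbon. Going by the values given here, no measured pair isolates this change. A moderate downward step is expected, a 2.4-fold lower number from compound 1 to compound 3 (0.39 log units; beyond the scatter), because compound 2 gives 42.5 nM while also carrying a five-membered aromatic ring with 1 hetero atom in place of the ring with 3 hetero atoms. Compound 3 is expected at 70 nM, within 25 nM to 200 nM.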

Compound 3, half-maximal inhibitory concentration: 59.5 nM
Beside the measured number, compound 3's estimate is 1.2-fold (0.07 log units) above it; low and high end bracket the measured number.
By their numbers in this assay, from the lowest: compounds 2 and 3 (each within the scatter of the next); then compound 1.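

At this position, on an aromatic carbon para to a large group and meta to a chloro group, one change can now be read on its own: in this assay thiophen-3-yl in place of the oxadiazolone-bearing ring gives a 2.9-fold lower number from compound 1 to compound 3 (0.46 log units; beyond the scatter) and the step lies beyond the scatter. The group that leaves carries 1 hydrogen-bond donor and the one that enters carries 0, so inhibition at this level does not depend on that donor being present here. No measurement on hand accounts for the size of this step.

Going by these compounds, it remains open whether phenyl, a pyridine ring or a carboxylic acid on this aromatic carbon would follow compound 3 or compound 1. Compound 2 differs from compound 3 in more than one place, so the contribution of its furan ring to inhibition also remains unresolved.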